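Moving the Ring Nitrogen in a Bicyclic Urea Substituent

The source may report more compounds than this note shows. Statements on the series, on what has been measured and on what is new or still open speak of the compounds shown alone.

Compound 1, `CN(C)C1(Cc2ccccc2)CCN(c2cc(C(F)(F)F)ccc2CNC(=O)Nc2cccc3[nH]c(=O)ccc23)CC1`: 30.6 nM
Compound 2, `CN(C)C1(Cc2ccccc2)CCN(c2cc(C(F)(F)F)ccc2CNC(=O)Nc2ccc3cccnc3c2)CC1`: 42 nM
Compound 3, `CN(C)C1(Cc2ccccc2)CCN(c2cc(C(F)(F)F)ccc2CNC(=O)Nc2ccc3ccncc3c2)CC1`: 56.1 nM

These three compounds share one core and differ only in the bicyclic group on the urea nitrogen. Within the data shown here, in an assay on CHO cells for antagonist activity at transient receptor potential cation channel subfamily V member 1 (Homo sapiens), read by scintillation counting, with a stated time of 5 min, in the presence of a further agent that is not named here (a lower number here means that less compound is needed, a higher number that more compound is needed for the effect), compound 3 gives the highest of the three numbers, yet its steps to the others, a 1.3-fold higher number from compound 2 to compound 3 (0.13 log units; within the scatter) and a 1.8-fold higher number from compound 1 to compound 3 (0.26 log units; within the scatter), both lie within the scatter, so no compound can be called more or less potent. Compound 4, `CN(C)C1(Cc2ccccc2)CCN(c2cc(C(F)(F)F)ccc2CNC(=O)Nc2cccc3ccncc23)CC1`, carries the change (isoquinolin-8-yl in place of isoquinolin-7-yl on an amide-type nitrogen). The step that bears most on this is a 1.3-fold higher number from compound 2 to compound 3 (0.13 log units; within the scatter), where exchanging one bicyclic isomer for another changed little; the step of a 1.4-fold higher number from compound 1 to compound 2 (0.14 log units; within the scatter) was also small. Compound 4 is therefore expected to show no step beyond the scatter, a 1.1-fold higher number from compound 3 to compound 4 (0.03 log units; within the scatter). The estimate for compound 4 in this assay is 60 nM, with a range from 25 nM to 150 nM.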

Compound 4, half-maximal effective concentration: 18.7 nM
For compound 4 the middle estimate is 3.2-fold (0.51 log units) above the measured one, outside the stated range (below it).
By their numbers in this assay, from the lowest: compounds 4, 1, 2 and 3 (each within the scatter of the next, the first and the last beyond it).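

In this assay, joining the same bicyclic group to the urea nitrogen differently, as isoquinolin-8-yl rather than isoquinolin-7-yl, gives a 3.0-fold lower number from compound 3 to compound 4 (0.48 log units; beyond the scatter), so at this position the point of attachment can shift the number modestly even with the same atoms. Isoquinolin-8-yl also gives a 2.2-fold lower number from compound 2 to compound 4 (0.35 log units; beyond the scatter) against quinolin-7-yl, while a 1.6-fold lower number from compound 1 to compound 4 (0.21 log units; within the scatter) leaves compound 4 and compound 1 indistinguishable. Nothing available explains why the attachment point matters. Still open, from the compounds shown here alone, is whether naphthalen-1-yl, with carbon in place of the ring nitrogen, would keep the number of compound 4.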